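Furan-3-yl for thiophen-2-yl in a weak antiproliferative pair

This account rests on a few compounds, and the source may have more. Where it says the series, first, only, none or still open, it means among the compounds named here.

Measured so far:
compound 1 `CN(C)c1ncnc2c1c(-c1ccoc1)cn2[C@@H]1O[C@H](CO)[C@@H](O)[C@H]1O` — 9060 nM
compound 2 `CNc1ncnc2c1c(-c1cccs1)cn2[C@@H]1O[C@H](CO)[C@@H](O)[C@H]1O` — > 20000 nM

Both numbers come from a functional assay on HeLa S3 cells (Homo sapiens) for antiproliferative activity, read by XTT assay, with a stated time of 72 h; on this read-out higher numbers stand for weaker inhibition and lower numbers for stronger inhibition. For compound 2 `CNc1ncnc2c1c(-c1cccs1)cn2[C@@H]1O[C@H](CO)[C@@H](O)[C@H]1O` the result is a limit of the assay, > 20000 nM, and not a number. Among the values shown, compound 2 stands at the limit of > 20000 nM in this assay, at which 1 of the 2 values shown sits. Compound 1 `CN(C)c1ncnc2c1c(-c1ccoc1)cn2[C@@H]1O[C@H](CO)[C@@H](O)[C@H]1O` gives a number in this assay, 9060 nM, which places it within the measured range.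

Within the data shown here, no pair of measured compounds here differs in only one place, and no measured step is therefore available to lean on. Compound 3 `CNc1ncnc2c1c(-c1ccoc1)cn2[C@@H]1O[C@H](CO)[C@@H](O)[C@H]1O` remains to be measured in this assay. Its difference from compound 2 is counted as furan-3-yl in place of thiophen-2-yl on an aromatic carbon.

With compound 2 resting on a limit, the size of the step to compound 3 cannot be read from the data; the expectation for this assay is a modest move toward stronger inhibition, an at least 1.3-fold lower number from compound 2 to compound 3 (0.12 log units; that floor lies within the scatter), which may or may not exceed the scatter. Compound 3 is estimated at 15000 nM, with a range from 6000 nM to 40000 nM.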

Compound 3, half-maximal inhibitory concentration: > 20000 nM
Compound 3: no number, only a limit (the forecaster's own chance of this, stated with the estimate: 45%); middle value at least 1.3-fold (0.12 log units) from the limit.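

In this assay compound 3 gives > 20000 nM, a limit of the assay and not a number. Furan-3-yl in place of thiophen-2-yl on this aromatic carbon therefore gives no readable step, as both compounds rest on limits: the limit of > 20000 nM in this assay, at which 2 of the 3 values shown sit. Among these compounds, the first readable step lies at the nitrogen on an aromatic ring and not at this carbon: with furan-3-yl held in place, hydrogen in place of methyl gives an at least 2.2-fold higher number from compound 1 to compound 3 (0.34 log units; beyond the scatter).

From the compounds shown here alone, whether either five-membered ring is better tolerated at this carbon remains open, as does whether the methyl-to-hydrogen step at the nitrogen would look the same with thiophen-2-yl in place of furan-3-yl. Also open is whether a longer chain on that nitrogen, such as ethyl or propyl, or a phenyl ring on the aromatic carbon would give a number in this assay stronger than that of the compounds shown.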